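A few compounds are considered here, and "the series" means these few. Any claim that something is new, unique, unknown or untested is made for them only; others in the source may bear on it.

Compound 3, with the structure `NC(=O)CCCCO`, sits second highest of the three numbers measured in an assay for inhibition of alcohol dehydrogenase (Equus caballus) (a higher number here means a weaker inhibitor, a lower number a stronger inhibitor), where compound 3 gives 4400000 nM. Compound 1, with the structure `CC[S+]([O-])c1ccccc1`, lies nearest to it: in this assay compound 1 gives 12500000 nM, a higher number, beyond the scatter. Compound 2, with the structure `CC(C)(C)CC(N)=O`, lies furthest: in this assay compound 2 gives 150000 nM, a much lower number, again beyond the scatter. The next compound is compound 4, with the structure `NC(=O)CCCCCO`, not yet measured in this assay. It differs from compound 3 in one place (hydroxymethyl in place of hydroxy on a saturated chain carbon, four bonds along the chain from a carbonyl carbon). No measured pair of this kind is available among these compounds, so the size of the step cannot be read from them. Compound 4 is expected to give a somewhat lower number than compound 3, a step of a 2.2-fold lower number from compound 3 to compound 4 (0.34 log units; beyond the scatter) close to the edge of the scatter, since compound 2 with 150000 nM shows that a larger saturated chain beside the amide can go with a lower number. For compound 4 the estimate in this assay is 2000000 nM, within a range from 600000 nM to 6000000 nM.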

Compound 4, inhibition constant: 1500000 nM
Compound 4: the middle estimate sits 1.3-fold (0.12 log units) above what was measured, and the stated range covers the measured number.
By their numbers in this assay, from the lowest: compound 2; then compound 4; then compound 3; then compound 1.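

In this assay, hydroxymethyl in place of hydroxy on a saturated chain carbon, four bonds along the chain from a carbonyl carbon, gives a 2.9-fold lower number from compound 3 to compound 4 (0.47 log units; beyond the scatter). For the compounds shown here, this is the first step between compounds that differ in one place, and it shows that the number at this position moves beyond the scatter, though modestly, with this change. The hydrogen-bond donor and acceptor counts of the leaving and entering groups are the same, so the step comes with a change that leaves those counts untouched, and nothing shown gives a reason for it.

A single step cannot show whether a longer chain, such as 2-hydroxyethyl in place of hydroxymethyl, would continue the same direction. It also leaves open how an amine or a carboxylic acid in place of the hydroxymethyl would compare.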